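A few compounds are considered here, and "the series" means these few. Any claim that something is new, unique, unknown or untested is made for them only; others in the source may bear on it.

Measured in a functional assay on AGS cells (Homo sapiens) for antiproliferative activity, read by MTT assay, with a stated time of 48 h; a lower number here means a stronger inhibitor of growth, a higher number a weaker inhibitor of growth:
Compound 1 `COc1ccc(Cn2cnc3c(Cl)ncnc32)cc1` gives 29000 nM.
Compound 2 `COc1ccc(Cn2cnc3c(Cl)ncnc32)cc1OC` gives > 100000 nM, which is a limit of this assay rather than a number.
Compound 3 `COc1cc(Cn2cnc3c(Cl)nc(Cl)nc32)cc(OC)c1` gives 3800 nM.

Compound 1 and compound 2 share a core and differ in one place: methoxy in place of hydrogen on an aromatic carbon. This change gave an at least 3.4-fold higher number from compound 1 to compound 2 (0.53 log units; beyond the scatter). The size of that step is known only as a bound, since the value of compound 2 is a limit (the limit of > 100000 nM in this assay, at which 1 of the 3 values shown sits).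

Compound 3 differs from compound 1 in more than one place, and the difference between the two cores is not broken down here. Of the two numbers measured, compound 3 gives the lower and compound 1 the higher.

Compound 4 `COc1cc(Cn2cnc3c(Cl)nc(Cl)nc32)cc(OC)c1OC` has not been measured. It differs from compound 3 by methoxy in place of hydrogen on an aromatic carbon. This is the same kind of change as from compound 1 to compound 2, though the surroundings differ: here the entering group sits ortho to two methoxy groups and para to a large group, whereas in compound 2 it sits ortho to a methoxy group and meta to a large group. A weakening is expected because the same kind of change gave an at least 3.4-fold higher number from compound 1 to compound 2 (0.53 log units; beyond the scatter). The expected step is a 3.9-fold higher number from compound 3 to compound 4 (0.60 log units; beyond the scatter). Compound 4 is estimated at 15000 nM, probably between 4000 nM and 80000 nM.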

Compound 4, concentration for 50% growth inhibition: 9400 nM
For compound 4 the middle estimate is 1.6-fold (0.20 log units) above the measured one; low and high end bracket the measured number.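

In this assay, placing a methoxy on an aromatic carbon in place of hydrogen again gave a weaker inhibitor of growth, with a 2.5-fold higher number from compound 3 to compound 4 (0.39 log units; beyond the scatter). The change therefore pointed the same way on both cores, and the two steps can be set side by side: the same change on two cores in this assay, an at least 3.4-fold higher number (0.53 log units; beyond the scatter) from compound 1 to compound 2 and a 2.5-fold higher number (0.39 log units; beyond the scatter) from compound 3 to compound 4; the limit leaves it open whether they differ. Compound 2 stands at a limit and not at a number, so this pair of cores shows the direction of the change but not whether it carries over with the same size: the limit of > 100000 nM in this assay, at which 1 of the 4 values shown sits.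

The compounds shown leave open whether the same direction would hold on a third core, since two cores are too few to make this a rule for the series. They also leave open what another group in the same place would do, such as a hydroxyl, an amine or a carboxylic acid, because every group added to the aromatic ring here is a methoxy: the same change on two cores in this assay, an at least 3.4-fold higher number (0.53 log units; beyond the scatter) from compound 1 to compound 2 and a 2.5-fold higher number (0.39 log units; beyond the scatter) from compound 3 to compound 4; the limit leaves it open whether they differ.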